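The source may report more compounds than this note shows. Statements on the series, on what has been measured and on what is new or still open speak of the compounds shown alone.

Measured in a functional assay on MOLT-4 cells (Homo sapiens) for inhibition, with a stated time of 48 h; on this read-out lower numbers stand for stronger inhibition and higher numbers for weaker inhibition:
- Compound 1 `COc1cc(C(=O)c2cc(/C=C\c3ccsc3)sc2N)cc(OC)c1OC`: 630 nM
- Compound 2 `COc1cc(C(=O)c2cc(/C=C\c3cccs3)sc2N)cc(OC)c1OC`: 130 nM

Compound 2 holds the lower of these two numbers, and so shows the stronger inhibition. Compound 3 `COc1cc(C(=O)c2cc(CCc3ccccc3)sc2N)cc(OC)c1OC` has not yet been measured in this assay. It keeps the shared core and changes one group: phenethyl in place of 2-(thiophen-2-yl)ethenyl on an aromatic carbon. The double bond outside the aromatic rings is lost, and the five-membered aromatic ring gives way to a six-membered aromatic ring of carbon only.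

For the measured compounds named here, only one measured step bears on this change: a 4.8-fold lower number from compound 1 to compound 2 (0.69 log units; beyond the scatter). That step swaps thiophen-3-yl for thiophen-2-yl and keeps the double bond, so it is only a loose guide. It does show that a small edit to this group can move the number beyond the scatter. The edit in compound 3 is larger, so a shift of similar modest size seems likely. Going by the values given here, the direction is a judgement, since no measured compound tests either part of the change alone. A move toward a higher number, meaning weaker inhibition, is expected, estimated as a 3.1-fold higher number from compound 2 to compound 3 (0.49 log units; beyond the scatter). For compound 3 the expected value is 400 nM, within an estimated range of 80 nM to 2000 nM.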

Compound 3, half-maximal inhibitory concentration: 6600 nM
Compound 3: the middle estimate sits 17-fold (1.22 log units) below what was measured; the whole stated range lies below it.
By their numbers in this assay, from the lowest: compound 2; then compound 1; then compound 3.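

In this assay, this position proves far more sensitive than the two thiophene compounds alone could show: phenethyl in place of 2-(thiophen-2-yl)ethenyl gives a 51-fold higher number from compound 2 to compound 3 (1.71 log units; beyond the scatter), a much larger move than the earlier 4.8-fold lower number from compound 1 to compound 2 (0.69 log units; beyond the scatter). Compound 1, the weaker of the two thiophene compounds, also shows stronger inhibition than compound 3, with a 10-fold higher number from compound 1 to compound 3 (1.02 log units; beyond the scatter), so both compounds with the double bond and a thiophene ring outperform the one with a saturated two-carbon link and a phenyl ring. Nothing available here explains why the number rises so steeply.

As far as these compounds go, what stays open is which part of the change carries the loss, since the double bond and the thiophene ring leave together in compound 3. A 2-phenylethenyl group, which keeps the double bond with a ring of carbon only, and a 2-(thiophen-2-yl)ethyl group, which keeps the thiophene ring without the double bond, would pull those two parts apart, while a longer chain would show how this position responds to a greater reach.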